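This account rests on a few compounds, and the source may have more. Where it says the series, first, only, none or still open, it means among the compounds named here.

Measured compounds:
compound 1, `FC(F)(F)c1cccc(-c2nc3cnc(Nc4ccncn4)cc3[nH]2)c1` — 200000 nM
compound 2, `FC(F)(F)c1cccc(-c2nc3cnc(Nc4cnccn4)cc3[nH]2)c1` — 155000 nM

In a physicochemical assay for solubility, using the shake flask method, measured as kinetic solubility, with a stated time of 20 h, at pH 2 (on this read-out lower numbers stand for lower solubility and higher numbers for higher solubility), compound 1 gives 200000 nM and compound 2 gives 155000 nM. Compound 2 stands alongside compound 1: the step of a 1.3-fold lower number from compound 1 to compound 2 (0.11 log units; within the scatter) is within the scatter, so the two numbers cannot be told apart. Compound 3, `FC(F)(F)c1cccc(-c2nc3cnc(Nc4cccnn4)cc3[nH]2)c1`, has not yet been measured in this assay. It differs from compound 2 by pyridazin-3-yl in place of pyrazin-2-yl on a nitrogen on an aromatic ring; cut one bond further out, the same difference reads (pyrazin-2-yl)amino to (pyridazin-3-yl)amino. Among the measured compounds shown here, the only measured step that bears on this change is a 1.3-fold lower number from compound 1 to compound 2 (0.11 log units; within the scatter), an exchange of one such aromatic ring for another at the same nitrogen, and it stayed within the scatter. The expected step in this assay is therefore a 1.2-fold higher number from compound 2 to compound 3 (0.06 log units; within the scatter), none beyond the scatter. Compound 3 is expected to give about 180000 nM, within a range from 80000 nM to 400000 nM.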

Compound 3, solubility: 161000 nM
Estimate against measurement, compound 3: 1.1-fold (0.05 log units) above, within the range that was stated.
By their numbers in this assay, from the lowest: compounds 2, 3 and 1 (each within the scatter of the next).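

In this assay, the exchange on a nitrogen on an aromatic ring gives a 1.0-fold higher number from compound 2 to compound 3 (0.02 log units; within the scatter), and the exchange of pyrimidin-4-yl for pyridazin-3-yl at the same place gives a 1.2-fold lower number from compound 1 to compound 3 (0.09 log units; within the scatter). Where the earlier compounds offered a single exchange, all three pairs among compounds 1, 2 and 3 now lie within the scatter, so these three six-membered aromatic rings with 2 hetero atoms cannot be told apart at this position in this read-out. No supporting measurement bears on why the numbers stay together.

It remains open whether a phenyl ring, a pyridin-2-yl ring or a saturated ring such as morpholine at this nitrogen would also stay within the scatter of these compounds. From the compounds shown here alone, it is also open whether the three would remain indistinguishable at a pH other than the one used here.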